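Cyclopropyl amide in a hexafluoro-carbinol naphthol series

The source may hold more compounds than are shown below. What is called first, only, known or untested is meant among the compounds shown, and "the series" means these compounds.

Measured compounds:
compound 1, `CCN(CC)C(=O)COc1ccc2cc(C(O)(C(F)(F)F)C(F)(F)F)c(O)cc2c1`, > 20000 nM
compound 2, `O=C(COc1ccc2cc(C(O)(C(F)(F)F)C(F)(F)F)c(O)cc2c1)Nc1ccccc1`, > 20000 nM
compound 3, `CC(C)c1ccc(NC(=O)COc2ccc3cc(C(O)(C(F)(F)F)C(F)(F)F)c(O)cc3c2)cc1`, 6500 nM

Three amides built on the shared core of compound 1 have been tested in an assay on isolated protein for inhibition of tyrosine-protein phosphatase non-receptor type 13 (Homo sapiens), read by spectrophotometry; on this read-out higher numbers stand for weaker inhibition and lower numbers for stronger inhibition. For compound 1 the result is only a limit, > 20000 nM. For compound 2 the result is likewise a limit, > 20000 nM. For the measured compounds named here, compound 3 alone gives a number, 6500 nM, and so stands as the only compound of the three with a readable value; the other two sit at the limit of > 20000 nM in this assay, at which 2 of the 3 values shown sit. The step of an at least 3.0-fold lower number from compound 2 to compound 3 (0.48 log units; beyond the scatter) and the step of an at least 3.0-fold lower number from compound 1 to compound 3 (0.48 log units; beyond the scatter) are both at least modest, while the step that the two limits leave unreadable from compound 1 to compound 2 cannot be read between two limits.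

Compound 4, `O=C(COc1ccc2cc(C(O)(C(F)(F)F)C(F)(F)F)c(O)cc2c1)NC1CC1`, carries cyclopropyl in place of 4-isopropylphenyl on an amide-type nitrogen. The measured steps bearing on it point one way: compound 2, with a plain anilino group, and compound 1, with diethylamino, both reach only the limit, and the isopropyl on the aromatic carbon is what separates compound 3 from them. Removing the whole 4-isopropylphenyl for a small cyclopropyl is therefore expected to move the number back up in this assay, by roughly a 3.1-fold higher number from compound 3 to compound 4 (0.49 log units; beyond the scatter). Compound 4 is estimated at 20000 nM, within 8000 nM to 60000 nM, with a fair chance that only a limit is reported.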

Compound 4, half-maximal inhibitory concentration: > 20000 nM
Compound 4 was reported as a limit (the forecaster's own chance of this, stated with the estimate: 55%); the middle value sits exactly at the limit.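

Exchanging 4-isopropylphenyl for cyclopropyl on the amide-type nitrogen gives an at least 3.0-fold higher number from compound 3 to compound 4 (0.48 log units; beyond the scatter) in this assay, and this size is bounded by a limit. The earlier compounds had shown that diethylamino and anilino gave no readable number, and this result extends that to a ring-bearing group with no aromatic ring: the cyclopropyl of compound 4 does not keep the readable value seen with 4-isopropylphenyl. The result for compound 4 is itself a limit, and it joins those of compound 1 and compound 2: the limit of > 20000 nM in this assay, at which 3 of the 4 values shown sit.

The steps to compound 4 from compound 1 and from compound 2 join two limits and cannot be read, so cyclopropyl cannot be ranked against diethylamino or anilino.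

The compounds shown leave open whether another group on that aromatic carbon, such as tert-butyl, methoxy or chlorine, would serve as isopropyl does in compound 3. They also leave open whether a larger saturated ring such as cyclohexyl, or a longer alkyl chain, on the amide-type nitrogen would give a readable number without any aromatic ring there.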